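This account rests on a few compounds, and the source may have more. Where it says the series, first, only, none or still open, it means among the compounds named here.

Three analogues sharing one core have been run in a functional assay on SMMC-7721 cells (Homo sapiens) for cytotoxicity, read by MTT assay, with a stated time of 72 h; a lower number here means a stronger inhibitor, a higher number a weaker inhibitor. Compound 1 `CCCCCOCNc1n[n+]([O-])c2ccccc2[n+]1[O-]` gives 17000 nM; compound 2 `[O-][n+]1nc(NCOCc2ccccc2)[n+]([O-])c2ccccc21` gives 20100 nM; compound 3 `COc1ccc(COCNc2n[n+]([O-])c3ccccc3[n+]2[O-])cc1` gives 22000 nM, the highest of the three numbers, yet separable from neither, since a 1.3-fold higher number from compound 1 to compound 3 (0.11 log units; within the scatter), a 1.1-fold higher number from compound 2 to compound 3 (0.04 log units; within the scatter) and a 1.2-fold higher number from compound 1 to compound 2 (0.07 log units; within the scatter). Compound 4 `CC(C)CCOCNc1n[n+]([O-])c2ccccc2[n+]1[O-]` differs from compound 3 by isobutyl in place of 4-methoxyphenyl on a saturated chain carbon bound to an oxygen on a saturated carbon. Going by the values given here, the step from compound 1 to compound 3 is the closest precedent: exchanging a chain for the 4-methoxyphenyl at this place stayed within the scatter, and isobutyl, like butyl, is a chain without a ring. Accordingly no step beyond the scatter is expected for this assay, a 1.3-fold lower number from compound 3 to compound 4 (0.11 log units; within the scatter). Compound 4 is expected to give 17000 nM, within 9000 nM to 34000 nM.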

Compound 4, half-maximal inhibitory concentration: 15900 nM
For compound 4 the middle estimate is 1.1-fold (0.03 log units) above the measured one; the measured number falls inside the stated range.
By their numbers in this assay, from the lowest: compounds 4, 1, 2 and 3 (each within the scatter of the next).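

In this assay, branching is new at this place: isopropyl in place of propyl (a 1.1-fold lower number from compound 1 to compound 4 (0.03 log units; within the scatter)) stays within the scatter. So do isobutyl in place of 4-methoxyphenyl (a 1.4-fold lower number from compound 3 to compound 4 (0.14 log units; within the scatter)) and isobutyl in place of phenyl (a 1.3-fold lower number from compound 2 to compound 4 (0.10 log units; within the scatter)), so across these four compounds neither a chain, a branched chain nor an aromatic ring separates from the others. No evidence bears on this result.

As far as these compounds go, whether an amine, a carboxylic acid or a much longer chain at this place would give a step beyond the scatter remains open. So does the effect of any change on the shared core.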